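A few compounds are considered here, and "the series" means these few. Any claim that something is new, unique, unknown or untested is made for them only; others in the source may bear on it.

Measured so far in an in vitro ADME assay on microsomes from liver (Simiiformes); a lower number here means that the compound disappears faster, a higher number that the compound lasts longer:
- compound 1 `CCc1cc(CCCOc2c(C)cc(-c3noc(C4CC4)n3)cc2C)on1`: 0.9 h
- compound 2 `COCc1cc(CCCOc2c(C)cc(-c3noc(C4CC4)n3)cc2C)on1`: > 2.5 h (a limit)

Compound 2 gives no number, only the limit > 2.5 h.

Compound 3 `Cc1cc(-c2noc(C3CC3)n2)cc(C)c1OCCCc1cc(C2CC2)no1` carries cyclopropyl in place of methoxymethyl on an aromatic carbon, next to the ring nitrogen (cyclopropyl in place of methoxymethyl on an aromatic carbon).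

Within the data shown here, one measured step bears on this: an at least 2.7-fold higher number from compound 1 to compound 2 (0.44 log units; beyond the scatter), with methoxy in place of methyl on the chain. Compound 3 loses that methoxymethyl, so a drop of similar size is expected in this assay, beyond the scatter.

The expected change is an at least 1.9-fold lower number from compound 2 to compound 3 (0.28 log units; that floor lies within the scatter).

For compound 3 the estimate is 1.3 h, with an expected range of 0.6 h to 2.8 h.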

Compound 3, half-life: > 2.5 h
Compound 3 ended at the assay's limit; the forecaster's own chance of this, stated with the estimate: 20%; at least 1.9-fold (0.28 log units) between middle value and limit.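

In this assay compound 3, with cyclopropyl in place of methoxymethyl on this aromatic carbon, gives > 2.5 h as a limit of the assay. The change from ethyl to cyclopropyl gives an at least 2.7-fold higher number from compound 1 to compound 3 (0.44 log units; beyond the scatter) and so shows that the rise over ethyl also appears with a group that has no hydrogen-bond acceptor.

Going by these compounds, how a trifluoromethyl or tert-butyl group would behave on this carbon stays open. The step from methoxymethyl to cyclopropyl cannot be read, and the two groups cannot be ranked, because both compounds end at the limit: the limit of > 2.5 h in this assay, at which 2 of the 3 values shown sit.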